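Tolerated concentration of bornyl esters bearing a piperazine tail

The source may report more compounds than this note shows. Statements on the series, on what has been measured and on what is new or still open speak of the compounds shown alone.

The measured compounds in an ADME assay on HEK-293T cells (Homo sapiens) for cytotoxicity, read by MTT assay, with a stated time of 48 h (a lower number here means that less compound is tolerated, a higher number that more compound is tolerated), are:
compound 1, `CN1CCN(CC(=O)O[C@@H]2C[C@@H]3CC[C@@]2(C)C3(C)C)CC1`, 313000 nM;
compound 2, `CN1CCN(CCCC(=O)O[C@@H]2C[C@@H]3CC[C@@]2(C)C3(C)C)CC1`, 99200 nM;
compound 3, `CCN1CCN(CC(=O)O[C@@H]2C[C@@H]3CC[C@@]2(C)C3(C)C)CC1`, 130000 nM.

Compound 1 and compound 3 differ in one place: methyl in place of hydrogen on a saturated chain carbon bound to an amine nitrogen in a ring. This change gave a 2.4-fold lower number from compound 1 to compound 3 (0.38 log units; beyond the scatter) in this assay. Compound 2 carries a longer chain between the ester and the ring amine than compound 1; the difference between the two cores is not broken down here. Compound 2 shows the lowest of the three numbers, and its value stands apart from that of compound 1 beyond the scatter, while it sits within the scatter of compound 3.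

Compound 4, `CCN1CCN(CCCC(=O)O[C@@H]2C[C@@H]3CC[C@@]2(C)C3(C)C)CC1`, has not yet been measured. It differs from compound 2 by methyl in place of hydrogen on a saturated chain carbon bound to an amine nitrogen in a ring, the same change that separates compound 3 from compound 1, made at the same kind of position on a saturated chain carbon bound to an amine nitrogen in a ring.

Among the measured compounds shown here, since the only example of this change, from compound 1 to compound 3, gave a modest step to a lower number, the expected step from compound 2 to compound 4 in this assay is a 2.1-fold lower number from compound 2 to compound 4 (0.32 log units; beyond the scatter), a little smaller than the earlier one because the starting point of compound 2 is already 99200 nM. Compound 4 is therefore estimated at 48000 nM, with a range from 22000 nM to 105000 nM.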

Compound 4, half-maximal cytotoxic concentration: 131000 nM
Estimate against measurement, compound 4: 2.7-fold (0.44 log units) below; the whole stated range lies below it.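

In this assay, among the compounds shown here, going from 4-methylpiperazin-1-yl to 4-ethylpiperazin-1-yl on the core of compound 2 gives a 1.3-fold higher number from compound 2 to compound 4 (0.12 log units; within the scatter), so on this core the extra methyl produces no step that can be told from the scatter. For the compounds shown here, this change therefore does not carry over in size from one core to the other, as the two steps differ by more than the scatter of such steps allows: the same change on two cores in this assay, a 2.4-fold lower number (0.38 log units; beyond the scatter) from compound 1 to compound 3 and a 1.3-fold higher number (0.12 log units; within the scatter) from compound 2 to compound 4, 3.2-fold (0.50 log units) apart, beyond the scatter of two such steps The result rests on only two pairs, so it shows that the outcome of this change depends on the core it is made on, but it does not show what in the cores is responsible, nor how the change would behave on a further core.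

The compounds shown leave open whether a propyl group in place of the ethyl would follow the step seen on the core of compound 1 or the flat result seen on the core of compound 2. They also leave open how the methyl and ethyl pair would compare on a longer chain than that of compound 2, which would show whether the gap between the two steps continues to grow with chain length.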